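This account rests on a few compounds, and the source may have more. Where it says the series, first, only, none or still open, it means among the compounds named here.

Of the compounds shown here, three that share a common core have been measured so far, each carrying a different group on the oxygen at a saturated carbon. Compound 1, `CC[C@@](C)(O)CC(=O)O[C@H](CC=C(C)C)C1=CC(=O)c2c(O)ccc(O)c2C1=O`, bears a (2-hydroxy-2-methylbutyl)carbonyl group there; in a functional assay on HeLa cells (Homo sapiens) for cytotoxicity, read by MTT assay (on this read-out lower numbers stand for stronger inhibition and higher numbers for weaker inhibition), compound 1 gives 17900 nM. Compound 2, `COC(C)CO[C@H](CC=C(C)C)C1=CC(=O)c2c(O)ccc(O)c2C1=O`, carries a 2-methoxypropyl group instead, and in this assay compound 2 gives 53400 nM. Compound 3, `CC(C)=CC[C@@H](OC(=O)C1CCOC1)C1=CC(=O)c2c(O)ccc(O)c2C1=O`, carries an (oxolan-3-yl)carbonyl group; in this assay compound 3 gives 73500 nM, the highest of the three numbers, though one of the two gaps is only a 1.4-fold higher number from compound 2 to compound 3 (0.14 log units; within the scatter), while the other is a 4.1-fold higher number from compound 1 to compound 3 (0.61 log units; beyond the scatter).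

Compound 4, `CC(C)=CC[C@@H](OC(=O)CC(O)c1ccccc1)C1=CC(=O)c2c(O)ccc(O)c2C1=O`, differs from compound 3 in one place: 2-hydroxy-2-phenylethyl in place of oxolan-3-yl on a carbonyl carbon. The measured step that bears most directly on this is the one on the same carbonyl carbon, a 4.1-fold higher number from compound 1 to compound 3 (0.61 log units; beyond the scatter), where a chain carrying a hydroxyl group was exchanged for the oxolan-3-yl ring and the number rose. Compound 4 brings a hydroxyl-bearing chain back onto that carbonyl carbon, so a modest move in the opposite direction is expected, roughly a 2.6-fold lower number from compound 3 to compound 4 (0.42 log units; beyond the scatter). Compound 4 is therefore estimated at 28000 nM in this assay, with a likely range from 9000 nM to 80000 nM.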

Compound 4, half-maximal inhibitory concentration: 44500 nM
Beside the measured number, compound 4's estimate is 1.6-fold (0.20 log units) below it; measured number inside the range.
By their numbers in this assay, from the lowest: compound 1; then compounds 4, 2 and 3 (each within the scatter of the next).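

At this position on the carbonyl carbon, a saturated oxygen-containing ring and an open chain carrying a hydroxyl group and a phenyl ring cannot be told apart in this assay: replacing oxolan-3-yl with 2-hydroxy-2-phenylethyl gives a 1.7-fold lower number from compound 3 to compound 4 (0.22 log units; within the scatter) and so no real change, even though the entering group has more heavy atoms and adds a hydrogen-bond donor. A hydroxyl group on the chain is also not enough to match compound 1, since compound 4 carries one too and exchanging the alkyl end of the chain for a phenyl ring gives a 2.5-fold higher number from compound 1 to compound 4 (0.40 log units; beyond the scatter), a modest step but one that can be read. No measurement available here accounts for either step.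

The hydroxyl group and the phenyl ring change together in these compounds, so a plain 2-phenylethyl chain with no hydroxyl group would be needed to separate what each contributes. Also open is how this position would respond to a chain ending in an amine or a carboxylic acid, which would test groups unlike any shown so far.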